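The source may hold more compounds than are shown below. What is called first, only, known or untested is meant among the compounds shown, and "the series" means these compounds.

Compound 1, `O=C(/C(=N/O)Nc1ccc(F)c(Br)c1)C1CCCCC1`, is a small oxime-bearing molecule built on a plain six-membered saturated carbon ring. In an assay for inhibition of Tryptophan 2,3-dioxygenase (Homo sapiens), with a stated time of 1 h (a higher number here means a weaker inhibitor, a lower number a stronger inhibitor), compound 1 gives 79300 nM, the highest of the two numbers reported, with compound 3, `O=C(/C(=N/O)Nc1ccc(F)c(Br)c1)C1CCN(C(=O)Nc2ccccc2)CC1`, standing within the scatter of it at 58000 nM. Compound 2, `O=C(/C(=N/O)Nc1ccc(F)c(Br)c1)[C@H]1CC[C@H](NS(=O)(=O)Nc2ccccc2)CC1`, reaches a limit of this assay at > 100000 nM, so no number is known for it. That limit, (the limit of > 100000 nM in this assay, at which 1 of the 3 values shown sits), is the only other result among the three.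

Compound 4, `NS(=O)(=O)NC[C@H]1CC[C@H](C(=O)/C(=N/O)Nc2ccc(F)c(Br)c2)CC1`, is obtained from compound 1 by the change ((sulfamoylamino)methyl in place of hydrogen on a saturated ring carbon). Compound 2 also carries a sulfur-containing group on the same saturated ring and sits at the limit. No change between two measured compounds matches this one, so the step is estimated on that showing alone: from compound 1 to compound 4 the expected step is a 1.2-fold higher number from compound 1 to compound 4 (0.08 log units; within the scatter), with no clear gain anticipated. Compound 4 is expected to give about 95000 nM in this assay, within a range from 40000 nM to 250000 nM.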

Compound 4, half-maximal inhibitory concentration: 58700 nM
Estimate against measurement, compound 4: 1.6-fold (0.21 log units) above; measured number inside the range.
By their numbers in this assay, from the lowest: compounds 3, 4 and 1 (each within the scatter of the next). At a limit, above all of these: compound 2.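

The ring carbon three ring bonds from the ring atom that bears a large group now has its first readable step. In this assay, placing (sulfamoylamino)methyl there instead of hydrogen gives a 1.4-fold lower number from compound 1 to compound 4 (0.13 log units; within the scatter), so this sizeable group, with its hydrogen-bond donors and acceptors, brings neither a clear gain nor a clear loss. Compound 2 carries a different sulfur-containing group on the ring, but it stands at a limit of the assay and gives no number to set beside this step: the limit of > 100000 nM in this assay, at which 1 of the 4 values shown sits.

The compounds shown leave open whether a smaller group at this ring carbon, such as an aminomethyl or a carboxylic acid, would move the number beyond the scatter. They also leave open whether a longer chain carrying the same sulfamoylamino end would do so.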